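Dienone–triazole–coumarin series: second methoxy on the new core

The source may report more compounds than this note shows. Statements on the series, on what has been measured and on what is new or still open speak of the compounds shown alone.

Measured so far in a functional assay on PC-3 cells (Homo sapiens) for inhibition, read by sulforhodamine B assay, with a stated time of 48 h, tested at 50 uM; on this read-out lower numbers stand for less inhibition of growth and higher numbers for more inhibition of growth at the one concentration tested:
compound 1, `COc1cccc(/C=C/C(=O)/C=C/c2ccc(OCc3cn(CCOc4cc(=O)oc5ccccc45)nn3)c(OC)c2)c1`, gives 13%
compound 2, `COc1cccc(/C=C/C(=O)/C=C/c2ccc(OCc3cn(CCCOc4cc(=O)oc5ccccc45)nn3)c(OC)c2)c1`, gives "not active" (no number reported)
compound 3, `COc1ccc(/C=C/C(=O)/C=C/c2ccc(OCc3cn(CCOc4cc(=O)oc5ccccc45)nn3)c(OC)c2)cc1OC`, gives 19%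

Compound 4, `COc1ccc(/C=C/C(=O)/C=C/c2ccc(OCc3cn(CCCOc4cc(=O)oc5ccccc45)nn3)c(OC)c2)cc1OC`, has not yet been measured in this assay.

Compound 2 and compound 1 share most of their structure, but how the two cores differ is not broken down here. Compound 3 differs from compound 1 by a single change, (methoxy in place of hydrogen on an aromatic carbon), and compound 4 differs from compound 2 by the same change, (methoxy in place of hydrogen on an aromatic carbon); the place described for both is the same word for word, so the two are the same change on two cores, and it occurs in both pairs of the series.

On the core of compound 1, this change gave a number 6 percentage points higher from compound 1 to compound 3 (within the scatter) in this assay, so compound 1 and compound 3 are not told apart by this read-out. Compound 2 stands at no single number in this assay, only as not active, so there is no measured starting point for the step to compound 4.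

For compound 4 the expectation rests on two points: the core of compound 2 gives "not active" (no number reported) in this assay, and the change itself moved the read-out by a number 6 percentage points higher from compound 1 to compound 3 (within the scatter), within the scatter. Compound 4 is therefore expected to stay low, with a real chance that it is again reported only as not active. Compound 4 is estimated at 8% in this assay, with a range from 0% to 20%.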

Compound 4, percent growth inhibition at one concentration: 9%
For compound 4 the middle estimate is 1 percentage points below the measured one; the measured number falls inside the stated range.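

Compound 2 is reported only as not active in this assay with no number, and compound 4 gives 9% there, so no new step can be read between them. The compounds shown leave open whether methoxy in place of hydrogen has any measurable effect on the core of compound 2. No measurement shown bears on the reason for this result.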